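Aryl-substituted thiazolidinones: chain substituent varied at the amine

This account rests on a few compounds, and the source may have more. Where it says the series, first, only, none or still open, it means among the compounds named here.

Two compounds of the series have numbers in a functional assay on aorta for inhibition of Voltage-dependent L-type calcium channel subunit alpha-1C (Rattus norvegicus); a lower number here means a stronger inhibitor, a higher number a weaker inhibitor. Compound 1 `CC(C)(C)c1cc(C2SCC(=O)N2CCCN)cc(C(C)(C)C)c1O` gives 4400 nM. Compound 2 `CN(C)CCN(C)CCCN1C(=O)CSC1c1cc(C(C)(C)C)c(O)c(C(C)(C)C)c1` gives 1700 nM, the lowest of the two, and the step of a 2.6-fold lower number from compound 1 to compound 2 (0.41 log units; beyond the scatter) shows that enlarging the substituent on the chain carbon brought a modest gain beyond the scatter. Compound 3 `CN(CCCN1C(=O)CSC1c1cc(C(C)(C)C)c(O)c(C(C)(C)C)c1)CC(O)COc1ccccc1` is not yet measured; it differs from compound 2 by 1-hydroxy-2-phenoxyethyl in place of (dimethylamino)methyl on a saturated chain carbon bound to an amine nitrogen. Within the data shown here, only the step from compound 1 to compound 2 bears on this, and it concerns a different part of the same chain end, so the guidance is weak. The gain of a 2.6-fold lower number from compound 1 to compound 2 (0.41 log units; beyond the scatter) came with a larger substituent, and compound 3 carries a larger group still, so a further small gain or no step beyond the scatter is expected; the step of a 1.7-fold lower number from compound 2 to compound 3 (0.23 log units; within the scatter) is estimated. Compound 3 is expected to give 1000 nM, within 300 nM to 3500 nM.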

Compound 3, half-maximal inhibitory concentration: 420 nM
The estimate for compound 3 lay 2.4-fold (0.38 log units) above the measured number; measured number inside the range.
By their numbers in this assay, from the lowest: compound 3; then compound 2; then compound 1.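

In this assay, putting 1-hydroxy-2-phenoxyethyl in place of (dimethylamino)methyl on a saturated chain carbon bound to an amine nitrogen gives a 4.0-fold lower number from compound 2 to compound 3 (0.61 log units; beyond the scatter). The chain end therefore does not need the terminal dimethylamino nitrogen of compound 2 for this gain, and it accepts a six-membered aromatic ring of carbon only together with a hydroxy group. The change removes one nitrogen and adds the ring, the hydroxy group and the ether oxygen at once, and nothing available explains the step.

The contribution of each added part remains unresolved, since no compound shown separates them. A 3-phenoxypropyl group without the hydroxy and a 2-hydroxypropyl group without the phenoxy ring would divide the step between those two parts.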